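Swapping the Aryl Group on a Shared Core

The source may report more compounds than this note shows. Statements on the series, on what has been measured and on what is new or still open speak of the compounds shown alone.

Among the compounds with values here, compound 1 `C#CCSc1nc(Nc2ccc(F)cc2)c2ccncc2n1` is the only compound here with a numerical result: in a functional assay on PC-3 cells (Homo sapiens) for inhibition, read by MTT assay, with a stated time of 72 h (a higher number here means a weaker inhibitor, a lower number a stronger inhibitor), compound 1 gives 17300 nM. Compound 2 `C#CCSc1nc(Nc2ccc([N+](=O)[O-])cc2)c2ccncc2n1` reaches only a limit of the assay in this assay, > 80000 nM, not a number. The step of an at least 4.6-fold higher number from compound 1 to compound 2 (0.66 log units; beyond the scatter) thus runs toward weaker inhibition. Compound 3 `C#CCSc1nc(Nc2ccccc2O)c2ccncc2n1` alters compound 1 in a different way: 2-hydroxyphenyl in place of 4-fluorophenyl on a nitrogen on an aromatic ring. Within the data shown here, no measured step tests this change directly, and the single step known, an at least 4.6-fold higher number from compound 1 to compound 2 (0.66 log units; beyond the scatter), weakened the inhibitor. A modest weakening is therefore expected, as a 1.4-fold higher number from compound 1 to compound 3 (0.16 log units; within the scatter). Compound 3 is estimated at 25000 nM, most likely between 8000 nM and 80000 nM.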

Compound 3, half-maximal inhibitory concentration: 18700 nM
Compound 3: middle estimate off by 1.3-fold (0.13 log units), on the high side; measured number inside the range.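

The step, a 1.1-fold higher number from compound 1 to compound 3 (0.03 log units; within the scatter), shows that 2-hydroxyphenyl can stand in place of 4-fluorophenyl on this nitrogen with no change that can be told from the scatter in this assay. Not every change away from compound 1 at this place, then, moves the number beyond the scatter. Compound 2 remains a limit of the assay, not a number: the limit of > 80000 nM in this assay, at which 1 of the 3 values shown sits.

The compounds shown leave open what 4-hydroxyphenyl, or an amine or a carboxylic acid on the phenyl ring, would do at this nitrogen. On these data alone, how far compound 2 truly lies from compound 1 also stays open.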